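Notes on amide substituents and maximal response

This account rests on a few compounds, and the source may have more. Where it says the series, first, only, none or still open, it means among the compounds named here.

Measured compounds:
compound 1 `C/C=C/C(=O)Nc1c(C(O)(C(F)(F)F)C(F)(F)F)ccc2ccccc12` gives 96%
compound 2 `O=C(Nc1c(C(O)(C(F)(F)F)C(F)(F)F)ccc2ccccc12)C1CC1` gives 100%
compound 3 `COCC(=O)Nc1c(C(O)(C(F)(F)F)C(F)(F)F)ccc2ccccc12` gives 93%

All three numbers come from a functional assay (Sus scrofa) with sulfonylurea receptors; K-ATP channels (Homo sapiens) as the target; on this read-out lower numbers stand for smaller maximal responses and higher numbers for larger maximal responses. Compound 1 sits between the other two: the step of a number 3 percentage points lower from compound 1 to compound 3 (within the scatter) and the step of a number 4 percentage points higher from compound 1 to compound 2 (within the scatter) both stay inside the scatter, as does a number 7 percentage points lower from compound 2 to compound 3 (within the scatter). Nothing in the three measured compounds separates one from another on this read-out.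

Compound 4 `Cc1cccc(C(=O)Nc2c(C(O)(C(F)(F)F)C(F)(F)F)ccc3ccccc23)c1` differs from compound 1 by 3-methylphenyl in place of prop-1-en-1-yl on a carbonyl carbon. The two measured steps that change the same place, prop-1-en-1-yl to cyclopropyl and prop-1-en-1-yl to methoxymethyl on the carbonyl carbon, were each within the scatter. Among the measured compounds shown here, the entering 3-methylphenyl is larger than either of those groups and brings an aromatic ring, for which no measured step exists here, so the basis is thinner than for the measured pairs.

On the measured steps, the step of a number 2 percentage points lower from compound 1 to compound 4 (within the scatter) is expected to stay within the scatter, in no particular direction. Compound 4 is therefore estimated at 94%, with a range from 78% to 106% in this assay.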

Compound 4, largest response reached (reported as efficacy), in percent of the reference or control that the assay uses: 97%
Estimate against measurement, compound 4: 3 percentage points below; low and high end bracket the measured number.
By their numbers in this assay, from the lowest: compounds 3, 1, 4 and 2 (each within the scatter of the next).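

In this assay, replacing the non-aromatic groups on the carbonyl carbon with an aromatic ring leaves the read-out within the scatter in all three comparisons: a number 1 percentage points higher from compound 1 to compound 4 (within the scatter), a number 4 percentage points higher from compound 3 to compound 4 (within the scatter) and a number 3 percentage points lower from compound 2 to compound 4 (within the scatter). Among the compounds shown here, the position therefore now spans prop-1-en-1-yl, cyclopropyl, methoxymethyl and the larger 3-methylphenyl, and none of these four groups separates from the others on maximal response, with no compound going against this. No supporting data are available to explain this result.

The compounds shown leave open whether an amine, a carboxylic acid or a longer alkyl chain on the carbonyl carbon would stay within the same scatter. They also leave open whether these four compounds differ in the concentration needed to reach their maximal response.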